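From Hydroxy to Propargyloxy: The Step to Compound 3

This account rests on a few compounds, and the source may have more. Where it says the series, first, only, none or still open, it means among the compounds named here.

In a functional assay on HCT-116 cells (Homo sapiens) for inhibition, read by sulforhodamine B assay, with a stated time of 48 h, tested at 50 uM (a lower number here means less inhibition of growth, a higher number more inhibition of growth at the concentration tested), compound 2 `COc1ccc([C@@H]2C/C(=N/O)c3cc(CC=C(C)C)c(OC)cc3O2)cc1` gives 47% while compound 1 `COc1ccc([C@@H]2C/C(=N/OCc3cn(-c4ccc(O)cc4)nn3)c3cc(CC=C(C)C)c(OC)cc3O2)cc1` gives 65% at the single concentration tested. Compound 2 is therefore the lower of the two, and the gap between them lies beyond the usual scatter of repeated measurements.

The next molecule is compound 3 `C#CCO/N=C1/C[C@@H](c2ccc(OC)cc2)Oc2cc(OC)c(CC=C(C)C)cc21` which differs from compound 2 in one place. That change is propargyl in place of hydrogen on an oxygen and it puts propargyl in place of hydrogen on an oxygen whose other neighbour is a double-bonded nitrogen. In short, hydroxy becomes propargyloxy.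

Within the data shown here, no measured pair shows this change yet, so any expectation rests on little. Among the measured compounds shown here, the one guide is that compound 1 reaches 65% and so shows that values above compound 2 are possible. A small rise therefore seems likelier than a fall. The expected step is a number 7 percentage points higher from compound 2 to compound 3 (within the scatter) and a rise this modest may not clear the usual scatter. Compound 3 is estimated to give 54% within a range of 38% to 70% of growth inhibition.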

Compound 3, percent growth inhibition at one concentration: 65%
The estimate for compound 3 lay 11 percentage points below the measured number; low and high end bracket the measured number.
By their numbers in this assay, from the lowest: compound 2; then compounds 1 and 3 (each within the scatter of the next).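

In this assay, putting propargyl in place of hydrogen on the oxygen whose other neighbour is a double-bonded nitrogen gives a number 18 percentage points higher from compound 2 to compound 3 (beyond the scatter). Among these compounds, this is the first single change measured at this oxygen, and it shows that a free hydroxy there is not needed for growth inhibition at the concentration tested. Comparing the groups carried on this oxygen's chain, ethynyl in place of 1-(4-hydroxyphenyl)-1H-1,2,3-triazol-4-yl gives no change at the digits printed from compound 1 to compound 3 (within the scatter), so this read-out does not tell the two groups apart, and nothing available explains either step.

As far as these compounds go, whether a plain methyl group or a longer chain in place of propargyl on this oxygen would give a similar number stays open, as does the effect of an amine at the end of such a chain. A reading at one concentration also leaves open whether compound 1 and compound 3 would stay alike at other concentrations, and so how closely their potencies really match.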